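Removing the Sulfate from a Long-Chain Glycoside

The source may report more compounds than this note shows. Statements on the series, on what has been measured and on what is new or still open speak of the compounds shown alone.

Three compounds were measured in a functional assay on U-373MG ATCC cells (Homo sapiens), read by thymidine incorporation; on this read-out lower numbers stand for stronger inhibition and higher numbers for weaker inhibition:

compound 1 `CCCCC(=O)N[C@H]1[C@@H](OCCc2ccccc2)O[C@H](COCC(CO)(CO)COS(=O)(=O)O)[C@@H](O)[C@@H]1O` gives 6.7 uM
compound 2 `CCCCCCCCCCCCCCCCO[C@H]1O[C@H](COCC(CO)(CO)COS(=O)(=O)O)[C@@H](O)[C@H](O)[C@H]1NC(=O)CCCC` gives 3.2 uM
compound 3 `CCCCC(=O)N[C@H]1[C@@H](OCCc2ccccc2)O[C@H](COCC(CO)(CO)CO)[C@@H](O)[C@@H]1O` reaches only the limit > 50 uM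

Compound 2 has the lowest of the two numbers, and compound 1 stands above it. How the cores of compound 1 and compound 2 differ is not broken down here. From compound 1 to compound 3 the change is hydrogen in place of sulfo on an oxygen on a saturated carbon, and it made a step of an at least 7.4-fold higher number from compound 1 to compound 3 (0.87 log units; beyond the scatter). Compound 4 `CCCCCCCCCCCCCCCCO[C@H]1O[C@H](COCC(CO)(CO)CO)[C@@H](O)[C@H](O)[C@H]1NC(=O)CCCC` carries the same change from compound 2, namely (hydrogen in place of sulfo on an oxygen on a saturated carbon). Compound 4 is expected to show a step of a 13-fold higher number from compound 2 to compound 4 (1.10 log units; beyond the scatter) because an at least 7.4-fold higher number from compound 1 to compound 3 (0.87 log units; beyond the scatter) shows what this change did on the core of compound 1. Compound 4 is therefore estimated at 40 uM, between 12 uM and 120 uM.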

Compound 4, concentration for 50% inhibition: 27.3 uM
Compound 4: middle estimate off by 1.5-fold (0.17 log units), on the high side; the measured number falls inside the stated range.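

In this assay the exchange of sulfo for hydrogen on the long-chain glycoside gives an 8.5-fold higher number from compound 2 to compound 4 (0.93 log units; beyond the scatter) and so weakens inhibition on this core. The change thus points the same way on both cores shown, and its size can be compared only loosely: the same change on two cores in this assay, an at least 7.4-fold higher number (0.87 log units; beyond the scatter) from compound 1 to compound 3 and an 8.5-fold higher number (0.93 log units; beyond the scatter) from compound 2 to compound 4; the limit leaves it open whether they differ. Compound 3 gives > 50 uM, which is a limit and not a number, so these two pairs show that the direction carried over but not that the size did.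

The compounds shown leave open whether a carboxylic acid or a phosphate in place of the sulfooxy group would keep the inhibition. They also leave open how the same change behaves on a core with a shorter alkyl chain on the glycoside oxygen.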